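Swapping a Spirocyclic Lactam for a Pyridine Amide

This account rests on a few compounds, and the source may have more. Where it says the series, first, only, none or still open, it means among the compounds named here.

Compound 1 `O=C(Nc1cnc(NCc2c(F)ccc3c2CCO3)n2cnnc12)c1ccccc1`: 10 mL.min-1.g-1
Compound 2 `CC1(C)CC(=O)N(c2cnc(NCc3c(F)ccc4c3CCO4)n3cnnc23)C1`: 16 mL.min-1.g-1
Compound 3 `O=C1CC2(CC2)CN1c1cnc(NCc2c(F)ccc3c2CCO3)n2cnnc12`: < 3 mL.min-1.g-1

These three compounds were measured in an ADME assay on microsomes from liver (Homo sapiens) for metabolic stability, read by LC-MS, using NADPH, with stated times of 5 min and 30 min, tested at 1 uM; on this read-out higher numbers stand for fast clearance and lower numbers for slow clearance. Compound 3 sits at the limit of < 3 mL.min-1.g-1 in this assay, at which 1 of the 3 values shown sits, so its value is a limit of the assay and not a number. Compound 4 `O=C(Nc1cnc(NCc2c(F)ccc3c2CCO3)n2cnnc12)c1cccnc1` has not yet been measured. The change from compound 3 to compound 4 is a group of 9 heavy atoms (6 carbon, 2 nitrogen, 1 oxygen; one six-membered aromatic ring with 1 hetero atom) in place of a group of 8 heavy atoms (6 carbon, 1 nitrogen, 1 oxygen; one three-membered non-aromatic ring of carbon only, one five-membered non-aromatic ring with 1 hetero atom), on an aromatic carbon. Within the data shown here, two measured steps bear on it: an at least 3.3-fold lower number from compound 1 to compound 3 (0.52 log units; beyond the scatter), and an at least 5.3-fold lower number from compound 2 to compound 3 (0.72 log units; beyond the scatter), which together place compound 3 at the slow-clearance end of the three. Compound 4 brings back an amide much like that of compound 1, with a ring nitrogen added, so a step back up in the number is expected: an at least 2.6-fold higher number from compound 3 to compound 4 (0.42 log units; beyond the scatter). Compound 4 is therefore expected to give 8 mL.min-1.g-1, with a range from 3 mL.min-1.g-1 to 20 mL.min-1.g-1.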

Compound 4, intrinsic clearance in microsomes: < 3 mL.min-1.g-1
Compound 4: no number, only a limit; the forecaster's own chance of this, stated with the estimate: 15%; middle value at least 2.6-fold (0.42 log units) from the limit.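

In this assay compound 4 sits at a limit of the assay, not at a number: the limit of < 3 mL.min-1.g-1 in this assay, at which 2 of the 4 values shown sit.

At this position an amide can therefore sit at the slow-clearance end too, and a single ring nitrogen makes the difference: pyridin-3-yl in place of phenyl on the carbonyl carbon gives an at least 3.3-fold lower number from compound 1 to compound 4 (0.52 log units; beyond the scatter). Replacing the lactam of the dimethyl compound with this amide gives an at least 5.3-fold lower number from compound 2 to compound 4 (0.72 log units; beyond the scatter).

The step between the two compounds at the limit cannot be read. Whether the place of the ring nitrogen matters stays open, as pyridin-2-yl and pyridin-4-yl amides are not among the compounds shown.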